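Removing the amide ring group from a cytotoxicity series

The source may hold more compounds than are shown below. What is called first, only, known or untested is meant among the compounds shown, and "the series" means these compounds.

Compound 1 `Cc1c(C)c2c(c(C)c1OC(=O)CCC(=O)O)CCC(C)(C(=O)NC1CC(C)(C)N([O])C(C)(C)C1)O2` gives 165000 nM in a functional assay on MT4 cells (Homo sapiens) for cytotoxicity, read by MTT assay, with a stated time of 72 h; a higher number here means a weaker inhibitor, a lower number a stronger inhibitor. Compound 3 `Cc1c(C)c2c(c(C)c1OC(=O)CCC(=O)NC1CC(C)(C)N([O])C1(C)C)CC[C@@](C)(CCC[C@H](C)CCC[C@H](C)CCCC(C)C)O2` gives 87000 nM, a number within the scatter of compound 1. Compound 2 `Cc1c(C)c2c(c(C)c1O)CCC(C)(C(=O)NC1CC(C)(C)N([O])C(C)(C)C1)O2` gives 55000 nM, and the gap from compound 1 lies beyond the scatter.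

The unmeasured compound 4 `Cc1c(C)c2c(c(C)c1OC(=O)CCC(=O)O)CCC(C)(C(=O)O)O2` differs from compound 1 at a single place: one oxygen atom in place of a group of 12 heavy atoms (9 carbon, 2 nitrogen, 1 oxygen; one six-membered non-aromatic ring with 1 hetero atom), on a carbonyl carbon. A hydroxy group enters on that carbonyl carbon, and the large ring-bearing group leaves.

Within the data shown here, only one measured step bears on this, and only indirectly. It is a 3.0-fold lower number from compound 1 to compound 2 (0.48 log units; beyond the scatter), where hydrogen takes the place of (2-carboxyethyl)carbonyl on an oxygen on an aromatic ring. That step is modest, and it happens at a different place in the molecule. Compound 4 keeps the (2-carboxyethyl)carbonyl group, so the step says nothing directly about the new change. Among the measured compounds shown here, no measured compound shows the loss of the ring-bearing group, so the data give no direction for it. No step beyond the scatter is therefore expected in this assay, though the uncertainty is wide. The expected step is a 1.2-fold higher number from compound 1 to compound 4 (0.08 log units; within the scatter). For compound 4 the estimated value is 200000 nM, with an expected range of 70000 nM to 500000 nM.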

Compound 4, half-maximal inhibitory concentration: 285000 nM
Estimate against measurement, compound 4: 1.4-fold (0.15 log units) below; measured number inside the range.
By their numbers in this assay, from the lowest: compounds 2, 3, 1 and 4 (each within the scatter of the next, the first and the last beyond it).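

Replacing the ring-bearing group with a hydroxy group on the carbonyl carbon gives a 1.7-fold higher number from compound 1 to compound 4 (0.24 log units; within the scatter) in this assay. Among these compounds, this is the first measured change at this position, and it shows that a group of 12 heavy atoms, including a six-membered non-aromatic ring, can leave without a step beyond the scatter, at least while the (2-carboxyethyl)carbonyl group stays in place. Nothing available explains why the number moves so little, and no measurement of any property of these compounds bears on the result.

The compounds shown leave open how the carbonyl carbon would read with something between these two extremes, such as a methyl ester, a simple methylamide or an amide carrying a plain cyclohexyl ring, and so whether any part of the departing group matters on its own. Among the compounds shown here, they also leave open whether the same exchange would give a similar step in a compound with a free hydroxy group on the aromatic ring, since the only measured step at that oxygen starts from compound 1 and keeps the ring-bearing group.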